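A few compounds are considered here, and "the series" means these few. Any claim that something is new, unique, unknown or untested is made for them only; others in the source may bear on it.

Of the compounds shown here, two carrying the shared core have been measured in a functional assay on the whole organism (strain CF-1) with Mus musculus as the target, in the writhing test, with a stated time of 15 min (on this read-out higher numbers stand for an effect only at larger amounts of compound and lower numbers for an effect already at smaller amounts), so far. Compound 1 `O=C(/N=C1\NC2(CCCCO2)CCS1)c1ccccc1` gives 5 mg/kg. Compound 2 `O=C(/N=C1\NC2(CCCCO2)CCS1)c1cccc(F)c1` gives 9.2 mg/kg; the change from hydrogen to fluoro on an aromatic carbon brought a 1.8-fold higher number from compound 1 to compound 2 (0.26 log units; within the scatter). Compound 2 thus holds the highest of the two numbers, and its nearest neighbour is compound 1, the gap between them being within the scatter.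

The next compound, compound 3 `O=C(/N=C1\NC2(CCCCO2)CCS1)c1cccc([N+](=O)[O-])c1`, differs from compound 2 by nitro in place of fluoro on an aromatic carbon. Among the measured compounds shown here, the only measured step that bears on this position is a 1.8-fold higher number from compound 1 to compound 2 (0.26 log units; within the scatter), and it stayed within the scatter; no step from fluoro to nitro has been measured on this core. On that basis the step of a 1.1-fold higher number from compound 2 to compound 3 (0.04 log units; within the scatter) is expected to stay within the scatter as well. Compound 3 is therefore estimated at 10 mg/kg, with a range from 4 mg/kg to 25 mg/kg.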

Compound 3, dose for half-maximal effect: > 200 mg/kg
Compound 3: a limit, no number; the forecaster's own chance of this, stated with the estimate: 10%; middle value at least 20-fold (1.30 log units) away from the limit.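

In this assay, compound 3 gives no number, only a limit of the assay: the limit of > 200 mg/kg in this assay, at which 1 of the 3 values shown sits.

This position, on an aromatic carbon meta to a large group, is therefore not indifferent to what it carries, as a 1.8-fold higher number from compound 1 to compound 2 (0.26 log units; within the scatter) alone had suggested. Nitro in place of fluoro gives an at least 21-fold higher number from compound 2 to compound 3 (1.33 log units; beyond the scatter), and nitro in place of hydrogen gives an at least 40-fold higher number from compound 1 to compound 3 (1.60 log units; beyond the scatter), so both steps are large and beyond the scatter, and their true size remains bounded on one side only.

Three compounds cannot show which feature of nitro goes with this loss, nor whether it is tied to this position on the aromatic ring. An amine, a methoxy group or a carboxylic acid at the same place could show whether the effect stays near that of compound 1 or falls away as with compound 3.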